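This account rests on a few compounds, and the source may have more. Where it says the series, first, only, none or still open, it means among the compounds named here.

In a functional assay on MCF7 cells (Homo sapiens) for cytotoxicity, read by MTT assay, with a stated time of 72 h (a lower number here means a stronger inhibitor, a higher number a weaker inhibitor), compound 3, whose structure is `COc1ccccc1/C=C1\CCC/C(=C\c2cccc(OC)c2OC)C1=O`, gives 12000 nM. Alongside it stand compound 1, with structure `COc1cccc(/C=C2\CCC/C(=C\c3cccc(Cl)c3)C2=O)c1OC`, which gives 12000 nM, and compound 2, with structure `COc1cccc(/C=C2\CCC/C(=C\c3ccc(Cl)cc3)C2=O)c1OC`, which gives 10300 nM. Compound 3 sits level with compound 1 at the digits shown, the two together being the highest of the three numbers, and its separation from compound 2 is a 1.2-fold higher number from compound 2 to compound 3 (0.07 log units; within the scatter). Every step among these three compounds stays within the usual scatter.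

Compound 4, with structure `COc1cccc(/C=C2\CCC/C(=C\c3ccc(Cl)c(Cl)c3)C2=O)c1OC`, has not yet been measured in this assay. It differs from compound 3 as follows: 3,4-dichlorophenyl in place of 2-methoxyphenyl on a double-bonded chain carbon bound to a double-bonded ring carbon.

Going by the values given here, the steps that bear on this change are those in which the same group on the double-bonded chain carbon was exchanged: from compound 1 to compound 3 the result was no change at the digits printed from compound 1 to compound 3 (within the scatter), and from compound 2 to compound 3 it was a 1.2-fold higher number from compound 2 to compound 3 (0.07 log units; within the scatter). Neither exchange moved the number beyond the scatter, so the step from compound 3 to compound 4 is expected to be a 1.1-fold lower number from compound 3 to compound 4 (0.04 log units; within the scatter), with no direction that can be trusted. Compound 4 is therefore estimated at 11000 nM in this assay. The expected range for compound 4 runs from 5000 nM to 24000 nM.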

Compound 4, half-maximal inhibitory concentration: 9000 nM
For compound 4 the middle estimate is 1.2-fold (0.09 log units) above the measured one, and the stated range covers the measured number.
By their numbers in this assay, from the lowest: compounds 4, 2, 1 and 3 (each within the scatter of the next).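

In this assay the position on the double-bonded chain carbon bound to a double-bonded ring carbon now takes a phenyl group bearing two chloro substituents, and replacing 2-methoxyphenyl with 3,4-dichlorophenyl gives a 1.3-fold lower number from compound 3 to compound 4 (0.12 log units; within the scatter) and so stays level. Putting chloro in place of hydrogen on an aromatic carbon gives a 1.1-fold lower number from compound 2 to compound 4 (0.06 log units; within the scatter) and also a 1.3-fold lower number from compound 1 to compound 4 (0.12 log units; within the scatter) so a second chloro adds nothing that can be told apart from either compound with a single chloro. The earlier compounds had shown only single substituents of this kind, whereas 3,4-dichlorophenyl, with two chlorine atoms and no hydrogen-bond acceptor, still cannot be separated from 2-methoxyphenyl, with one oxygen and one hydrogen-bond acceptor, by this assay at this position.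

Every group shown here is a phenyl ring carrying chloro or methoxy, so it remains open whether a phenyl ring bearing an amine or a carboxylic acid, or a longer chain in its place, would move the number beyond the scatter. Nothing measured on these compounds speaks to why the numbers stay level.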